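The source may hold more compounds than are shown below. What is called first, only, known or untested is meant among the compounds shown, and "the series" means these compounds.

Measured compounds:
compound 1 `COc1cc2c(cc1OC)C(CC(=O)N(C)C)CC2` — 33.3%
compound 2 `COc1cc2c(cc1OC)C(CC(=O)NC(C)C)CC2` — 37%

In a functional assay on the whole organism (strain Wistar) for inhibition, with Rattus norvegicus as the target, read by paw edema, with stated times of 60 min and 6 h, at a dose of 100 mg/kg by the oral route (a higher number here means more inhibition at the dose given (going by the name of the read-out), a lower number less inhibition), compound 1 gives 33.3% and compound 2 gives 37%. The single measured step, a number 3.7 percentage points higher from compound 1 to compound 2 (within the scatter), lies within the scatter, so on the numbers shown compound 2 cannot be told apart from compound 1; the two stand together.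

Compound 3 `CCCCCNC(=O)CC1CCc2cc(OC)c(OC)cc21` differs from compound 2 by pentyl in place of isopropyl on an amide-type nitrogen. For the measured compounds named here, the only step that bears on this change is the one from compound 1 to compound 2, which also alters the group on the amide-type nitrogen; its size, a number 3.7 percentage points higher from compound 1 to compound 2 (within the scatter), was within the scatter. From that one step, a further change of the group on the amide-type nitrogen is expected to move the number by no more than the scatter, in no settled direction, so the expected step of no change at the digits printed from compound 2 to compound 3 (within the scatter) is close to nothing. Compound 3 is therefore estimated at 37%, with a range from 22% to 52%.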

Compound 3, a percentage reported as inhibition, in the whole organism at one dose (the size of the read-out at that dose, not a potency): 35.2%
The estimate for compound 3 lay 1.8 percentage points above the measured number; low and high end bracket the measured number.
By their numbers in this assay, from the lowest: compounds 1, 3 and 2 (each within the scatter of the next).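

In this assay, pentyl in place of isopropyl on the amide-type nitrogen gives a number 1.8 percentage points lower from compound 2 to compound 3 (within the scatter), and pentylamino in place of dimethylamino on the carbonyl carbon gives a number 1.9 percentage points higher from compound 1 to compound 3 (within the scatter). The earlier pair covered only small groups on this nitrogen; with a pentyl chain of 5 carbons, the three compounds still cannot be told apart, so this change of chain leaves the inhibition at this dose unresolved from that of the smaller groups. Nothing available explains this result.

From the compounds shown here alone, whether a different kind of group on this nitrogen, such as a chain ending in an amine or a carboxylic acid, or a phenyl ring, would move the number beyond the scatter stays open. Going by these compounds, since each number comes from a single dose, it also stays open whether these compounds would separate at other doses.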